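A few compounds are considered here, and "the series" means these few. Any claim that something is new, unique, unknown or untested is made for them only; others in the source may bear on it.

Compound 1 `Cc1[nH]c2ccccc2c(=O)c1Cc1ccccc1` is the most permeable of the three measured compounds: in an ADME assay for permeability, using PAMPA, at pH 7.4 (a lower number here means that the compound crosses the layer more slowly, a higher number that the compound crosses the layer faster), compound 1 gives 102 10^-6 cm/s. Compound 2 `Cc1[nH]c2ccccc2c(=O)c1Br` gives 13.6 10^-6 cm/s in this assay, and compound 3 `COc1ccc2[nH]c(C)c(Br)c(=O)c2c1` gives 16.7 10^-6 cm/s. The difference between the core of compound 1 and the core of compound 2 is not broken down here. Compound 3 differs from compound 2 by methoxy in place of hydrogen on an aromatic carbon, and that change gave a 1.2-fold higher number from compound 2 to compound 3 (0.09 log units; within the scatter). Compound 4 `COc1ccc2c(=O)c(Cc3ccccc3)c(C)[nH]c2c1`, not yet measured, differs from compound 1 by the same change, (methoxy in place of hydrogen on an aromatic carbon). Because a 1.2-fold higher number from compound 2 to compound 3 (0.09 log units; within the scatter) lay within the scatter, the step from compound 1 to compound 4 in this assay is expected to be similarly small, a 1.1-fold higher number from compound 1 to compound 4 (0.05 log units; within the scatter). Compound 4 is therefore estimated to give 115 10^-6 cm/s, expected between 60 10^-6 cm/s and 210 10^-6 cm/s.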

Compound 4, apparent permeability: 240 10^-6 cm/s
Beside the measured number, compound 4's estimate is 2.1-fold (0.32 log units) below it, and the stated range ends below it.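

In this assay methoxy in place of hydrogen on an aromatic carbon gave a 2.4-fold higher number from compound 1 to compound 4 (0.37 log units; beyond the scatter) on the core of compound 1. Set beside the earlier step, the two results cannot be told apart: the same change on two cores in this assay, a 1.2-fold higher number (0.09 log units; within the scatter) from compound 2 to compound 3 and a 2.4-fold higher number (0.37 log units; beyond the scatter) from compound 1 to compound 4, 1.9-fold (0.28 log units) apart, within the scatter of two such steps. The change therefore carried from one core to the other with no measurable difference in the size of its step, but one step on each of two cores does not show that the steps are equal or that the same would hold on other cores in the series.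

Methoxy is the only group shown making this change. The compounds leave open what an amine, a carboxylic acid or a longer chain in place of hydrogen on an aromatic carbon would give on either core.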